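Bromo substitution on the methylsulfanyl ring of the oxazole series

The compounds below may be only part of what the source reports. "The series", "measured", "known", "first", "only" and "open" are said of these compounds alone.

Of the compounds shown here, three have been measured in a functional assay on MCF7 cells (Homo sapiens) for cytotoxicity, read by MTT assay, with a stated time of 48 h; on this read-out lower numbers stand for stronger inhibition and higher numbers for weaker inhibition. Compound 1 `COc1ccc(-c2ocnc2-c2cc(OC)c(OC)c(OC)c2)cc1S` gives 2110 nM. Compound 2 `COc1cc(/C=C\c2cccc(OC)c2SC)cc(OC)c1OC`, an open stilbene-type analogue of the same aryl pair, gives 650 nM. Compound 3 `COc1cc(-c2ocnc2-c2cc(OC)c(OC)c(OC)c2)ccc1SC` gives 600 nM, the lowest of the three numbers. Compound 2 stands within the scatter of compound 3, so the two cannot be separated on this read-out; compound 1 stands beyond the scatter, with the higher number of the pair.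

Compound 4 `COc1cc(-c2ncoc2-c2cc(Br)c(SC)c(OC)c2)cc(OC)c1OC` is the next step from compound 3. The change is bromo in place of hydrogen on an aromatic carbon. The carbon that takes the bromo is ortho to a methylsulfanyl group, meta to a methoxy group and meta to the large group; the rest of the structure, including the shared core and the trimethoxyphenyl ring, is unchanged.

For the measured compounds named here, no measured pair in this set isolates a bromo-for-hydrogen exchange, so the size of this step has no precedent here. The expectation is a step in this assay that is small, either direction, and not clearly beyond the scatter: a 1.2-fold lower number from compound 3 to compound 4 (0.08 log units; within the scatter). On that basis compound 4 is estimated at 500 nM, with a range from 150 nM to 1800 nM.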

Compound 4, half-maximal inhibitory concentration: 1420 nM
The estimate for compound 4 lay 2.8-fold (0.45 log units) below the measured number, and the stated range covers the measured number.
By their numbers in this assay, from the lowest: compounds 3 and 2 (each within the scatter of the next); then compounds 4 and 1 (each within the scatter of the next).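

In this assay, bromo in place of hydrogen on the aromatic carbon that is ortho to a methylsulfanyl group, meta to a methoxy group and meta to the large group gives a 2.4-fold higher number from compound 3 to compound 4 (0.37 log units; beyond the scatter) and so moves the number in the direction of weaker inhibition. For the compounds shown here, this is the first comparison that differs in one place, and it shows that this carbon does not tolerate every substituent without a change in the read-out: a single added bromine atom is enough to take the number beyond the scatter, though the step remains modest. Nothing available on these compounds bears on the cause of this step.

The compounds shown leave open whether the higher number is specific to bromo or would also follow from fluoro, chloro, methyl or a nitrile on the same carbon. They also leave open whether bromo on another carbon of this ring, or on the trimethoxyphenyl ring, would give a step of similar size and the same direction.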